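From Chlorophenyl Amide to Piperidinyl Urea on a Shared Core

This account rests on a few compounds, and the source may have more. Where it says the series, first, only, none or still open, it means among the compounds named here.

In an assay on HEK293 cells for negative allosteric modulation of metabotropic glutamate receptor 5 (Homo sapiens), read by FLIPR, with a stated time of 1 h (on this read-out higher numbers stand for weaker inhibition and lower numbers for stronger inhibition), three compounds share one core and differ only in the group on the carbonyl carbon. Compound 1 `C(#Cc1nc2c(s1)CN(C1CCCCC1)CC2)c1ccccc1` reaches only a limit of > 10000 nM rather than a number. Compound 2 `O=C(CC1CCOCC1)N1CCc2nc(C#Cc3ccccc3)sc2C1` likewise reaches only a limit of > 10000 nM. Compound 3 `O=C(c1cccc(Cl)c1)N1CCc2nc(C#Cc3ccccc3)sc2C1` again reaches only a limit of > 10000 nM. The step that the two limits leave unreadable from compound 2 to compound 3 cannot be read because the limit of > 10000 nM in this assay, at which 3 of the 3 values shown sit, holds every value shown. Compound 4 `O=C(N1CCCCC1)N1CCc2nc(C#Cc3ccccc3)sc2C1` carries piperidin-1-yl in place of 3-chlorophenyl on a carbonyl carbon. Within the data shown here, no measured step has a readable size, so neither direction nor size of the coming change can be taken from the data. Compound 4 is expected to give 15000 nM, within 5000 nM to 50000 nM. The step that the limit leaves unreadable from compound 3 to compound 4 is expected to leave the read-out at its limit.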

Compound 4, half-maximal inhibitory concentration: > 10000 nM
Compound 4 ended at the assay's limit; the forecaster's own chance of this, stated with the estimate: 85%; the middle value lies beyond the limit too.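

In this assay, no new step can be read from compound 1, compound 2 or compound 3 to compound 4, because all four stop at one limit: the limit of > 10000 nM in this assay, at which 4 of the 4 values shown sit.

The compounds shown leave open which group, if any, on the shared core would give a readable value.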